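Dichlorophenyl for difluorophenyl on the acyl carbonyl

A few compounds are considered here, and "the series" means these few. Any claim that something is new, unique, unknown or untested is made for them only; others in the source may bear on it.

Working notes on a small hydrazone series tested on gastric carcinoma cells. Compound 1 `CN(C(=O)NC(=O)c1ccc(F)c(F)c1)c1nc(C(F)(F)F)c(C(=O)N/N=C/c2ccccc2C(F)(F)F)s1` and compound 2 `CN(C(=O)NC(=O)c1ccc(F)c(F)c1)c1nc(C(F)(F)F)c(C(=O)N/N=C/c2cc(C(F)(F)F)cc(C(F)(F)F)c2)s1` both carry the ((3,4-difluorophenyl)carbonyl)amino group; how their two cores differ beyond that is not broken down here. In a functional assay on BCG823 cells (Homo sapiens) for inhibition, read by MTT assay, with a stated time of 72 h (a lower number here means a stronger inhibitor, a higher number a weaker inhibitor), compound 1 gives 3.66 ug/mL, and compound 2 gives 3.51 ug/mL, the two values lying within the scatter of each other. Compound 3 `CN(C(=O)NC(=O)c1ccc(Cl)cc1Cl)c1nc(C(F)(F)F)c(C(=O)N/N=C/c2cc(C(F)(F)F)cc(C(F)(F)F)c2)s1` is compound 2 with 2,4-dichlorophenyl in place of 3,4-difluorophenyl on a carbonyl carbon. In this assay compound 3 gives > 100 ug/mL, which is a limit of the assay and not a number. The step of an at least 28-fold higher number from compound 2 to compound 3 (1.45 log units; beyond the scatter) therefore runs up to the limit of > 100 ug/mL in this assay, at which 1 of the 3 values shown sits.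

Compound 4 `CN(C(=O)NC(=O)c1ccc(Cl)cc1Cl)c1nc(C(F)(F)F)c(C(=O)N/N=C/c2ccccc2C(F)(F)F)s1` has not been measured yet; it is compound 1 with 2,4-dichlorophenyl in place of 3,4-difluorophenyl on a carbonyl carbon. The place of the change reads the same in both pairs, so the same change is made twice among the compounds shown, once measured and once not. A step of the same direction and size is expected, a 41-fold higher number from compound 1 to compound 4 (1.61 log units; beyond the scatter), because an at least 28-fold higher number from compound 2 to compound 3 (1.45 log units; beyond the scatter) is large and because compound 1 at 3.66 ug/mL sits within the scatter of compound 2 at 3.51 ug/mL. Compound 4 is therefore estimated to give 150 ug/mL in this assay. The estimate for compound 4 spans from 40 ug/mL to 500 ug/mL, with a strong chance that only a limit is reported.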

Compound 4, half-maximal inhibitory concentration: 5.73 ug/mL
Estimate against measurement, compound 4: 26-fold (1.42 log units) above, outside the stated range (below it).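

In this assay the change from 3,4-difluorophenyl to 2,4-dichlorophenyl on the core of compound 1 gives a 1.6-fold higher number from compound 1 to compound 4 (0.19 log units; within the scatter), so the large step seen on the other core does not carry over to this one, and the two steps differ: the same change on two cores in this assay, an at least 28-fold higher number (1.45 log units; beyond the scatter) from compound 2 to compound 3 and a 1.6-fold higher number (0.19 log units; within the scatter) from compound 1 to compound 4, at least 18-fold (1.26 log units) apart, beyond the scatter of two such steps. Compound 3 gives > 100 ug/mL, which is a limit of the assay and not a number, so the step on that core has a known lower bound but no known size: the limit of > 100 ug/mL in this assay, at which 1 of the 4 values shown sits. The result shows that in this series the effect of this change depends on the core it is made on, but two pairs do not show which feature of the cores decides the outcome, nor how the change would behave on any further core.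

The compounds shown leave open whether the steep loss on the core of compound 2 is tied to the two chlorines together or would also appear with an unsubstituted phenyl or a single chlorine on that ring. As far as these compounds go, it also remains open how either core would respond to a quite different acyl group, such as one carrying an amine or a carboxylic acid.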